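Shortening an Ester Chain: Expected Effect on Protease Inhibition

The compounds below may be only part of what the source reports. "The series", "measured", "known", "first", "only" and "open" are said of these compounds alone.

Compound 1 `CCCOC(=O)c1ccc(CN)cc1` and compound 2 `CCCCCOC(=O)c1ccc(CN)cc1` share a core and differ only in the chain of the ester. In an assay on isolated protein for inhibition of serine protease 1 (Homo sapiens) (on this read-out lower numbers stand for stronger inhibition and higher numbers for weaker inhibition), compound 1 gives 500000000 nM, and in this assay compound 2 gives 700000000 nM. The step of a 1.4-fold higher number from compound 1 to compound 2 (0.15 log units; within the scatter), ethyl in place of hydrogen on a saturated chain carbon, three bonds along the chain from an oxygen next to a carbonyl group, thus makes no difference that can be trusted; compound 2 and compound 1 cannot be told apart here. Compound 3 `CCOC(=O)c1ccc(CN)cc1` is obtained from compound 2 by hydrogen in place of propyl on a saturated chain carbon, two bonds along the chain from an oxygen next to a carbonyl group. Going by the values given here, the only measured step that bears on this, a 1.4-fold higher number from compound 1 to compound 2 (0.15 log units; within the scatter), stayed within the scatter, so shortening the chain is expected to leave this assay essentially unchanged, perhaps slightly lower. Compound 3 is therefore expected to give 450000000 nM, with a range from 200000000 nM to 1000000000 nM, meaning an expected step of a 1.6-fold lower number from compound 2 to compound 3 (0.19 log units; within the scatter).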

Compound 3, inhibition constant: 357000000 nM
For compound 3 the middle estimate is 1.3-fold (0.10 log units) above the measured one, and the stated range covers the measured number.
By their numbers in this assay, from the lowest: compounds 3, 1 and 2 (each within the scatter of the next).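

Going down to the ethyl chain of compound 3 gives, in this assay, a 2.0-fold lower number from compound 2 to compound 3 (0.29 log units; within the scatter) even though hydrogen replaces a whole propyl group, the largest change at this position among the compounds shown. The smaller change, hydrogen in place of methyl, gives a 1.4-fold lower number from compound 1 to compound 3 (0.15 log units; within the scatter) and likewise stays within the scatter. Compounds with ethyl, propyl and pentyl chains therefore cannot be told apart, no trend with chain length can be claimed, and nothing available explains this flat result.

Going by these compounds, what stays open is whether a chain longer than pentyl or a shorter methyl ester would move the number beyond the scatter. On these data alone, it is also open whether a carboxylic acid or an amide in place of the ester would do so.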